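Swapping Isobutyl for Cyclohexyl on a Weak Inhibitor

The source may report more compounds than this note shows. Statements on the series, on what has been measured and on what is new or still open speak of the compounds shown alone.

Of the compounds shown here, two sharing one core have been tested in a functional assay on NCI-H460 cells (Homo sapiens) for antiproliferative activity, read by MTT assay, with a stated time of 48 h; a lower number here means a stronger inhibitor, a higher number a weaker inhibitor. Compound 1 `Cc1ccc(Nc2ccc3c(c2)C(CC2CCCCC2)C(=O)N3)cc1` reaches only the limit of the assay, > 100000 nM, so no number exists for it, and the limit of > 100000 nM in this assay, at which 1 of the 2 values shown sits, marks how much of the shown data sits at that ceiling. Going by the values given here, compound 2 `CC(C)CCC1C(=O)Nc2ccc(Nc3ccc(Cl)cc3)cc21` gives 48700 nM in this assay, the only actual number so far, and a weak one. Compound 3 `O=C1Nc2ccc(Nc3ccc(Cl)cc3)cc2C1CC1CCCCC1` has not yet been measured. It keeps the core of compound 2 and changes one group: cyclohexyl in place of isobutyl on a saturated chain carbon bound to a saturated ring carbon. Among the compounds with values here, no measured pair shows this swap on its own, so its size is unknown. Given that compound 2 is already weak, the step of a 1.2-fold higher number from compound 2 to compound 3 (0.09 log units; within the scatter) is expected to be small or to run toward weaker inhibition. Compound 3 is therefore estimated at about 60000 nM, in a range from 20000 nM to 200000 nM, with a fair chance that only a limit is reported.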

Compound 3, half-maximal inhibitory concentration: > 100000 nM
Compound 3 gave a limit, no number; the forecaster's own chance of this, stated with the estimate: 40%; middle value at least 1.6-fold (0.22 log units) from the limit.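

In this assay, cyclohexyl in place of isobutyl on a saturated chain carbon bound to a saturated ring carbon gives an at least 2.0-fold higher number from compound 2 to compound 3 (0.31 log units; beyond the scatter), the first sign that this position responds to a change of group, and here the change weakens inhibition. Compound 3 reached only a limit, so the true step may be larger than this. The swap of chloro in place of methyl on an aromatic carbon, which links the other pair, cannot be read, and the data now mostly end at a ceiling: the limit of > 100000 nM in this assay, at which 2 of the 3 values shown sit.

As far as these compounds go, it remains open whether any group at this position can give stronger inhibition than compound 2, which stands at 48700 nM. A longer chain or a chain ending in an amine would test this.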